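The source may report more compounds than this note shows. Statements on the series, on what has been measured and on what is new or still open speak of the compounds shown alone.

Within the data shown here, in an ADME assay on HPLF cells (Homo sapiens) for cytotoxicity, with a stated time of 24 h (on this read-out lower numbers stand for higher toxicity in this test and higher numbers for lower toxicity in this test), only two compounds have been measured so far. Compound 1 `CN(C)c1ccc(/C=C2\CCC/C(=C\c3ccccc3[N+](=O)[O-])C2=O)cc1` gives > 400000 nM, and this is a limit of the assay rather than a number. Among the measured compounds shown here, compound 2 `O=C1/C(=C/c2ccc(Cl)cc2)CCC/C1=C\c1cccc([N+](=O)[O-])c1` gives 38000 nM, the only true number available, so its standing cannot be judged against another numbered value.

Compound 3 `COc1ccc(/C=C2\CCC/C(=C\c3cccc([N+](=O)[O-])c3)C2=O)cc1` differs from compound 2 in one place: methoxy in place of chloro on an aromatic carbon. This puts methoxy in place of chloro on an aromatic carbon, para to a large group, turning 4-chlorophenyl into 4-methoxyphenyl.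

For the measured compounds named here, no measured pair isolates this change, and compound 1 and compound 2 differ in more than one place, so the data give no direct size for the step. The expectation is therefore anchored on compound 2 at 38000 nM: a small rise in the half-maximal cytotoxic concentration, meaning somewhat lower toxicity in this test, and possibly no more than the usual scatter of this assay. The estimated step is a 1.8-fold higher number from compound 2 to compound 3 (0.27 log units; within the scatter). For compound 3 the expected value is 70000 nM, with an estimated range of 20000 nM to 300000 nM.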

Compound 3, half-maximal cytotoxic concentration: 354000 nM
The estimate for compound 3 lay 5.1-fold (0.70 log units) below the measured number; the measured number lies above the stated range.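

In this assay, methoxy in place of chloro on an aromatic carbon, para to a large group, gives a 9.3-fold higher number from compound 2 to compound 3 (0.97 log units; beyond the scatter), so this position is not indifferent in this test. Among these compounds, this is the first single change that can be read directly, and it goes toward lower toxicity in this test for 4-methoxyphenyl than for 4-chlorophenyl. The new number also stands close to the ceiling already met in this series: the limit of > 400000 nM in this assay, at which 1 of the 3 values shown sits.

The compounds shown leave open whether the rise belongs to methoxy itself or would also appear with another group at this place, such as a hydroxyl, a primary amine or a fluorine. They also leave open whether a step of this size would hold on a different version of the shared core, as the reading rests on one pair alone.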